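Swapping the Piperidine Amine for Diisopropylamino

A few compounds are considered here, and "the series" means these few. Any claim that something is new, unique, unknown or untested is made for them only; others in the source may bear on it.

Measured so far in a functional assay on the whole organism (heart) with Rattus norvegicus as the target; a higher number here means that more compound is needed for the effect, a lower number that less compound is needed:
- Compound 1 `CC(=O)/C(=C\c1ccccc1)Oc1ccccc1OCCCN1CCN(C)CC1`: 2.5 mg/kg
- Compound 2 `CC(=O)/C(=C\c1ccccc1)Oc1ccc(OCC(O)NC(C)(C)C)cc1`: 3.5 mg/kg
- Compound 3 `CC(=O)/C(=C\c1ccccc1)Oc1ccccc1OCCCN1CCCCC1`: 0.2 mg/kg

Compound 3 stands lowest of the three, and compound 1 and compound 2 both lie well above it, beyond the scatter. The next structure, compound 4 `CC(=O)/C(=C\c1ccccc1)Oc1ccccc1OCCCN(C(C)C)C(C)C`, keeps everything in compound 3 except the amine group. The difference is diisopropylamino in place of piperidin-1-yl on a saturated chain carbon, three bonds along the chain from an oxygen on an aromatic ring.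

For the measured compounds named here, one measured step bears directly on this place: a 13-fold lower number from compound 1 to compound 3 (1.10 log units; beyond the scatter). That step was large, so an exchange of amine group here has already moved this assay well beyond the scatter. Going by the values given here, it involved two ring amines, however, whereas the incoming diisopropylamino group has no ring, and no measured compound carries that group. Compound 2 differs from compound 3 in more than one place and gives no direct guide.

With compound 3 at the low end of the measured values, some loss is the likelier outcome, and a moderate rise in this assay is expected, smaller than the earlier large step. The estimated change is a 2.5-fold higher number from compound 3 to compound 4 (0.40 log units; beyond the scatter). The expected value for compound 4 is 0.5 mg/kg, with an estimated range of 0.15 mg/kg to 2 mg/kg.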

Compound 4, dose for half-maximal effect: 0.1 mg/kg
For compound 4 the middle estimate is 5.0-fold (0.70 log units) above the measured one; the measured number lies below the stated range.
By their numbers in this assay, from the lowest: compounds 4 and 3 (each within the scatter of the next); then compounds 1 and 2 (each within the scatter of the next).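

In this assay, the exchange at this place now reaches beyond ring amines: the step of a 2.0-fold lower number from compound 3 to compound 4 (0.30 log units; within the scatter) shows that diisopropylamino, which has no ring, cannot be told apart from piperidin-1-yl on a saturated chain carbon, three bonds along the chain from an oxygen on an aromatic ring. The ring of compound 3 is therefore not needed to hold this level, at least for these two amine groups. By contrast, the step of a 25-fold lower number from compound 1 to compound 4 (1.40 log units; beyond the scatter) is large, as is the step of a 13-fold lower number from compound 1 to compound 3 (1.10 log units; beyond the scatter) and so, of the three amine groups compared here, 4-methylpiperazin-1-yl alone stands apart.

No evidence is at hand that accounts for these differences. Still open, on these data alone, is whether other open-chain amines such as dimethylamino or diethylamino, or ring amines such as pyrrolidin-1-yl or morpholin-4-yl, would hold the same level, and what a longer chain carrying diisopropylamino would do in this assay.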